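Removing One Chloro Group: From Compound 2 to Compound 3

A few compounds are considered here, and "the series" means these few. Any claim that something is new, unique, unknown or untested is made for them only; others in the source may bear on it.

Compound 2, `COc1ccccc1/C=c1\c(=O)[nH]/c(=C/c2cccc(Cl)c2Cl)c(=O)n1C`: 200 nM
Compound 1, `C=CCn1c(=O)/c(=C\c2cccc(C)c2)[nH]c(=O)/c1=C\c1ccccc1OC`: 20700 nM

Of the compounds shown here, two have been measured in a functional assay on MCF7 cells (Homo sapiens) for cytotoxicity, read by CCK-8 assay, with a stated time of 72 h; on this read-out higher numbers stand for weaker inhibition and lower numbers for stronger inhibition. Compound 2 gives 200 nM, the lowest of the two numbers. Within the data shown here, compound 1 gives 20700 nM, a gap to compound 2 that lies well beyond the scatter of repeated measurements; the two structures differ in several places at once, so no single step between them can be read.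

Compound 3, `COc1ccccc1/C=c1\c(=O)[nH]/c(=C/c2ccccc2Cl)c(=O)n1C`, has not yet been measured. It differs from compound 2 by hydrogen in place of chloro on an aromatic carbon, which, taken one bond further out, reads as 2,3-dichlorophenyl to 2-chlorophenyl. Among the measured compounds shown here, no measured pair shows this change, so the expectation rests on compound 2 alone. The estimate for compound 3 is a moderate rise in the number, expected as a 3.0-fold higher number from compound 2 to compound 3 (0.48 log units; beyond the scatter), since the starting point of compound 2 at 200 nM is the lowest known here. Compound 3 is therefore estimated at 600 nM, within a range from 150 nM to 3000 nM.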

Compound 3, half-maximal inhibitory concentration: 200 nM
The estimate for compound 3 lay 3.0-fold (0.48 log units) above the measured number; the measured number falls inside the stated range.
By their numbers in this assay, from the lowest: compounds 2 and 3 (each within the scatter of the next); then compound 1.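

In this assay, among these compounds, the only step that can be read between compounds differing in one place shows no change at the digits printed from compound 2 to compound 3 (within the scatter) when hydrogen takes the place of chloro on an aromatic carbon. On this read-out, 2,3-dichlorophenyl and 2-chlorophenyl therefore cannot be told apart, something the earlier pair, which differs in several places at once, could not show. No measurement available here accounts for this result.

The compounds shown leave open whether the remaining chloro group on the 2-chlorophenyl ring can also give way to hydrogen without a shift beyond the scatter. They also leave open how an amine or a carboxylic acid on the aromatic carbon that lost its chloro group would read in this assay.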